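Chloro to bromo: notes on compound 3 and compound 4

The source may report more compounds than this note shows. Statements on the series, on what has been measured and on what is new or still open speak of the compounds shown alone.

Measured in an assay (Populus sieboldii x Populus grandidentata) for inhibition of Trans-cinnamate 4-monooxygenase (Populus kitakamiensis), with a stated time of 60 min; on this read-out higher numbers stand for weaker inhibition and lower numbers for stronger inhibition:
compound 1 `S=c1[nH]nc(-c2cccc3ccccc23)o1`: > 100000 nM
compound 2 `Sc1nnc(-c2ccc3ccccc3c2)o1`: > 100000 nM
compound 3 `Sc1nnc(-c2ccccc2Cl)o1`: 680 nM

The value of compound 1 is a limit of the assay, not a number. The same holds for compound 2. Within the data shown here, compound 3 therefore gives the only number in this assay, the other two values being (the limit of > 100000 nM in this assay, at which 2 of the 3 values shown sit).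

Compound 4 `Sc1nnc(-c2ccccc2Br)o1` is not yet measured. It differs from compound 3 by bromo in place of chloro on an aromatic carbon. Among the measured compounds shown here, no measured pair of this kind exists, so in this assay the expected step is none beyond the scatter, in either direction. Compound 4 is expected at 550 nM, within a range of 200 nM to 1500 nM. The expected step of a 1.2-fold lower number from compound 3 to compound 4 (0.09 log units; within the scatter) is estimated to lie within the usual scatter.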

Compound 4, half-maximal inhibitory concentration: 980 nM
The estimate for compound 4 lay 1.8-fold (0.25 log units) below the measured number, within the range that was stated.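

In this assay bromo in place of chloro gives a 1.4-fold higher number from compound 3 to compound 4 (0.16 log units; within the scatter) on an aromatic carbon ortho to a group of 6 heavy atoms. This first measured pair shows that this position accepts either halogen with no step beyond the scatter, which compound 3 alone could not show. No measurement shown bears on the reason for this. Still open is whether a halogen is needed here at all, since the compounds shown do not include a methoxy group, an amine or a carboxylic acid on this carbon.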